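Cyano on the pyridine across two linker types

This account rests on a few compounds, and the source may have more. Where it says the series, first, only, none or still open, it means among the compounds named here.

Measured compounds:
compound 1, `O=C(Cc1ccccn1)c1cc2n(n1)CCCC2`, 390 nM
compound 2, `N#Cc1ccc(CC(=O)c2cc3n(n2)CCCC3)nc1`, 53 nM
compound 3, `O=C(Nc1ccccn1)c1cc2n(n1)CCCC2`, 364 nM

In a functional assay on HEK293 cells for negative allosteric modulation of metabotropic glutamate receptor 5 (Rattus norvegicus), read by FLIPR and calcium flux, with a stated time of 170 s (a lower number here means a stronger inhibitor, a higher number a weaker inhibitor), compound 1 gives 390 nM, and compound 2 gives 53 nM. The change between them is cyano in place of hydrogen on an aromatic carbon; it made a step of a 7.4-fold lower number from compound 1 to compound 2 (0.87 log units; beyond the scatter). Compound 3 carries a different linker from compound 1; how the two cores differ is not broken down here. In this assay compound 3 gives 364 nM, and compound 1 gives 390 nM, so the two stand within the scatter of each other.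

Compound 4, `N#Cc1ccc(NC(=O)c2cc3n(n2)CCCC3)nc1`, has not yet been measured. It differs from compound 3 by cyano in place of hydrogen on an aromatic carbon, the same change that turned compound 1 into compound 2, at the same place. Going by the values given here, on that single precedent, the step from compound 3 to compound 4 in this assay is expected to be about a 6.1-fold lower number from compound 3 to compound 4 (0.78 log units; beyond the scatter), close in size to a 7.4-fold lower number from compound 1 to compound 2 (0.87 log units; beyond the scatter), though only one example supports it. Compound 4 is therefore estimated at 60 nM, with a range from 25 nM to 150 nM.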

Compound 4, half-maximal inhibitory concentration: 90 nM
Beside the measured number, compound 4's estimate is 1.5-fold (0.18 log units) below it, within the range that was stated.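

Placed on the core of compound 3, cyano in place of hydrogen on an aromatic carbon gave, in this assay, a 4.0-fold lower number from compound 3 to compound 4 (0.61 log units; beyond the scatter), a step in the same direction as the one seen on the core of compound 1, and the two can be set side by side: the same change on two cores in this assay, a 7.4-fold lower number (0.87 log units; beyond the scatter) from compound 1 to compound 2 and a 4.0-fold lower number (0.61 log units; beyond the scatter) from compound 3 to compound 4, 1.8-fold (0.26 log units) apart, within the scatter of two such steps. In this pair, then, the change carried from one core to the other in direction and, within the scatter, in size. Two cores are a narrow base, however, and this neither shows that a similar step would appear on any further core nor explains how the cyano group produces it.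

The compounds shown leave open what a chlorine atom, a methoxy group or a carboxylic acid would do at the same place on the ring. They also leave open whether the cyano group would give a similar step on another carbon of that ring, or with a longer chain in the linker.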